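Swapping Fluorine for Chlorine in a Series Near the Limit

This account rests on a few compounds, and the source may have more. Where it says the series, first, only, none or still open, it means among the compounds named here.

Compound 1 `O=C(CNc1ccccc1F)N[C@H]1CCOC1=O`, compound 2 `O=C(CNc1ccc(F)cc1)N[C@H]1CCOC1=O` and compound 3 `O=C(CNc1ccccc1Cl)N[C@H]1CCOC1=O` were tested in a functional assay on MCF7 cells (Homo sapiens) for antiproliferative activity, read by MTT assay, with a stated time of 72 h; a lower number here means a stronger inhibitor, a higher number a weaker inhibitor. For compound 1 the assay reports only its limit, > 64000 nM. Compound 2 likewise reaches only a limit, > 64000 nM. Compound 3 too gives only a limit, > 64000 nM. The change from compound 1 to compound 3 is chloro in place of fluoro on an aromatic carbon, and it made a step that the two limits leave unreadable from compound 1 to compound 3 because every value sits at the limit of > 64000 nM in this assay, at which 3 of the 3 values shown sit. The difference between the cores of compound 1 and compound 2 is not broken down here. Compound 4 `O=C(CNc1ccc(Cl)cc1)N[C@H]1CCOC1=O` carries the same kind of change, (chloro in place of fluoro on an aromatic carbon), though here the chloro is para to a large group rather than ortho to a large group. Beside the measured step, the expected step is a step that the limit leaves unreadable from compound 2 to compound 4, which rests only on the same change having given a step that the two limits leave unreadable from compound 1 to compound 3. Compound 4 is expected at 100000 nM, between 64000 nM and 400000 nM.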

Compound 4, half-maximal inhibitory concentration: > 64000 nM
Compound 4: a limit, no number; the forecaster's own chance of this, stated with the estimate: 90%; the middle value is on the limit's open side.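

No step can be read from compound 2 to compound 4, as both results are limits and not numbers, because every value stands at the same limit: the limit of > 64000 nM in this assay, at which 4 of the 4 values shown sit.

The compounds shown leave open whether chloro in place of fluoro changes activity in this assay at all.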